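The compounds below may be only part of what the source reports. "The series", "measured", "known", "first", "only" and "open" are said of these compounds alone.

Three measured compounds share one core. Compound 1 `O=C1C(Nc2cccc(Cl)c2)=CC(=O)c2c1nc1n2[C@H]2OC[C@@H](O)[C@H]2OC1` carries a (3-chlorophenyl)amino group, and in a functional assay on ECa-109 cells for inhibition, with ECa-109 cell line (Homo sapiens) as the target, read by sulforhodamine B assay (a higher number here means a weaker inhibitor, a lower number a stronger inhibitor), compound 1 gives 3080 nM. Compound 2 `CCc1ccc(NC2=CC(=O)c3nc4n(c3C2=O)[C@H]2OC[C@@H](O)[C@H]2OC4)cc1` gives 3080 nM, so compound 1 stands level with compound 2 at the digits shown, within the scatter. Compound 3 `COc1ccc(NC2=CC(=O)c3nc4n(c3C2=O)[C@H]2OC[C@@H](O)[C@H]2OC4)cc1` returns only a limit of the assay, > 4000 nM. Among the measured compounds shown here, the single one-point step, an at least 1.2-fold higher number from compound 2 to compound 3 (0.11 log units; that floor lies within the scatter), therefore rests on the limit of > 4000 nM in this assay, at which 1 of the 3 values shown sits, and sets a floor that lies within the scatter.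

Compound 4 `CCCN(CCC)C1=CC(=O)c2c(nc3n2[C@H]2OC[C@@H](O)[C@H]2OC3)C1=O` has not yet been measured. It differs from compound 1 by dipropylamino in place of (3-chlorophenyl)amino on a double-bonded ring carbon. For the measured compounds named here, none of the measured steps exchanges a (3-chlorophenyl)amino group for a dipropylamino group; the only step swaps methoxy for ethyl on an aromatic carbon and stayed within the scatter, so no measured step bears directly on this change. With no direct guide, the expectation is a number near compound 1, with wide uncertainty in either direction. Compound 4 is therefore expected to give 3500 nM, between 1000 nM and 12000 nM. That would mean an expected step of a 1.1-fold higher number from compound 1 to compound 4 (0.06 log units; within the scatter), within the scatter.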

Compound 4, half-maximal inhibitory concentration: > 16000 nM
Compound 4: a limit, no number (the forecaster's own chance of this, stated with the estimate: 40%); middle value at least 4.5-fold (0.66 log units) from the limit.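

In this assay, among the compounds shown here, the group on this double-bonded ring carbon turns out to matter, which the earlier compounds could not show: swapping (3-chlorophenyl)amino for dipropylamino gives an at least 5.1-fold higher number from compound 1 to compound 4 (0.71 log units; beyond the scatter), the only step here that lies beyond the scatter. The swap takes away the aromatic ring and the hydrogen-bond donor together, and the chain-bearing group that enters is of similar size by heavy-atom count. The true size of the step remains unknown, as compound 4 gives a limit of the assay and not a number: the limit of > 16000 nM in this assay, at which 1 of the 4 values shown sits.

Going by these compounds, it stays open whether the ring, the amino hydrogen or both account for the step. A propylamino group, which keeps that hydrogen without a ring, and an N-methyl-N-phenylamino group, which keeps the ring without that hydrogen, could separate the two.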